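The compounds below may be only part of what the source reports. "The series", "measured", "known", "first", "only" and "open" are said of these compounds alone.

Measured so far:
compound 1 `CC(C)(N)C(=O)N[C@H](COCc1ccccc1)c1nnn(Cc2cccc(NS(C)(=O)=O)c2)n1`: 868 nM
compound 2 `CC(C)(N)C(=O)N[C@H](COCc1ccccc1)c1nnn(C/C=C/c2ccccc2)n1`: 517 nM

Both numbers come from a functional assay on H4 cells for agonist activity at growth hormone secretagogue receptor type 1 (Homo sapiens), read by FLIPR; a higher number here means that more compound is needed for the effect, a lower number that less compound is needed. Compound 2 holds the lower of the two, but the step of a 1.7-fold lower number from compound 1 to compound 2 (0.23 log units; within the scatter) is within the scatter, so the two compounds are not set apart.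

Compound 3 `CC(C)(N)C(=O)N[C@H](COCc1ccccc1)c1nnn(CC#N)n1` differs from compound 2 by cyano in place of 2-phenylethenyl on a saturated chain carbon bound to an aromatic nitrogen. Among the measured compounds shown here, the only measured step at this place, from compound 1 to compound 2, exchanged one aromatic-ring-bearing group for another and stayed within the scatter; no measured step removes the ring altogether. For compound 3 a higher number is therefore expected, estimated as a 2.9-fold higher number from compound 2 to compound 3 (0.46 log units; beyond the scatter). Compound 3 is expected to give 1500 nM, within the range 500 nM to 6000 nM.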

Compound 3, half-maximal effective concentration: 1520 nM
Compound 3: the middle estimate sits 1.0-fold (0.01 log units) below what was measured; measured number inside the range.
By their numbers in this assay, from the lowest: compounds 2, 1 and 3 (each within the scatter of the next, the first and the last beyond it).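

In this assay, among the compounds shown here, cyano on a saturated chain carbon bound to an aromatic nitrogen gives the first step at this place that lies beyond the scatter (a 2.9-fold higher number from compound 2 to compound 3 (0.47 log units; beyond the scatter)), so replacing 2-phenylethenyl with this smaller, ring-free group does register. Against 3-(methanesulfonamido)phenyl, the same group gives a step within the scatter (a 1.8-fold higher number from compound 1 to compound 3 (0.24 log units; within the scatter)), so having no aromatic ring does not set compound 3 apart from every ring-bearing compound. Nothing shown here accounts for either step.

The compounds leave open how an amine, a carboxylic acid or a longer chain ending in a nitrile would read at this place. They also leave open whether a simple phenyl group would match 2-phenylethenyl.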